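A Chloro-to-Methyl Swap Carried Over to a Second Core

This account rests on a few compounds, and the source may have more. Where it says the series, first, only, none or still open, it means among the compounds named here.

Of the compounds shown here, three have been measured in a physicochemical assay for lipophilicity, at pH 7.4; a lower number here means a more polar compound, a higher number a more lipophilic compound. Compound 1 `CC(C)Nc1nc(NCc2ccco2)c2ccc(Cl)cc2n1` gives 3.91. Compound 3 `Cc1ccc2c(NCc3ccco3)nc(NC(C)C)nc2c1` gives 3.61; it differs from compound 1 by methyl in place of chloro on an aromatic carbon, and that change produced a number 0.30 log units lower from compound 1 to compound 3 (within the scatter). Compound 2 `CC(C)Nc1nc(NCc2ccco2)c2cc(Cl)ccc2n1` gives 3.99 in this assay; the difference between its core and the core of compound 1 is not broken down here. Compound 4 `Cc1ccc2nc(NC(C)C)nc(NCc3ccco3)c2c1` has not yet been measured. It differs from compound 2 by methyl in place of chloro on an aromatic carbon, the same change that took compound 1 to compound 3, at the same kind of place. Because the earlier step was a number 0.30 log units lower from compound 1 to compound 3 (within the scatter), a step of similar size is expected here: a number 0.30 log units lower from compound 2 to compound 4 (within the scatter). The estimate for compound 4 in this assay is therefore 3.69, expected to fall between 3.4 and 4.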

Compound 4, distribution coefficient: 3.63
Beside the measured number, compound 4's estimate is 0.06 log units above it, within the range that was stated.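

In this assay, methyl in place of chloro on an aromatic carbon gave a number 0.36 log units lower from compound 2 to compound 4 (beyond the scatter), in the same direction as a number 0.30 log units lower from compound 1 to compound 3 (within the scatter). Within the data shown here, this shows that the change moved the number the same way on both cores, but only two pairs stand behind that reading, and one of the two steps lies within the usual scatter. No measurement shown here bears on what lies behind either step.

The compounds shown leave open whether another group in place of chloro, such as trifluoromethyl or an amine, would behave like methyl. They also leave open whether the same step would appear on a third core.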